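From Compound 2 to Compound 3: a Swap of Aryl Groups

The compounds below may be only part of what the source reports. "The series", "measured", "known", "first", "only" and "open" are said of these compounds alone.

Of the compounds shown here, two have been tested in an ADME assay on HUVEC cells (Homo sapiens) for antiproliferative activity, read by MTT assay, with a stated time of 48 h; on this read-out higher numbers stand for weaker inhibition and lower numbers for stronger inhibition. Compound 1 `Cc1ccc(-n2nncc2CN2C(=O)C3(C(C#N)=C(N)Oc4c3c3nc5ccccc5nc3c3ccccc43)c3ccccc32)cc1C` returns only a limit in this assay, > 50000 nM. Compound 2 `N#CC1=C(N)Oc2c(N)cc3nc4ccccc4nc3c2C12C(=O)N(Cc1cnnn1-c1ccccc1Br)c1ccccc12` gives 34200 nM in this assay. Within the data shown here, that is the only number in the set; the other entry is a limit, (the limit of > 50000 nM in this assay, at which 1 of the 2 values shown sits), so compound 2 stands alone as the single quantified point, at a weak level of inhibition. Compound 3 `Cc1ccc(C)c(-n2nncc2CN2C(=O)C3(C(C#N)=C(N)Oc4c(N)cc5nc6ccccc6nc5c43)c3ccccc32)c1` has not yet been measured; it differs from compound 2 by 2,5-dimethylphenyl in place of 2-bromophenyl on an aromatic nitrogen. Among the measured compounds shown here, no step between measured compounds is available, and the two values show only that compound 2 is weak while compound 1 sits at the limit. The change is expected to yield a step that is small, within the scatter or drifting toward weaker inhibition, a 1.2-fold higher number from compound 2 to compound 3 (0.07 log units; within the scatter). Compound 3 is therefore estimated at 40000 nM, with a range from 18000 nM to 90000 nM, and a real chance that this assay again reports only a limit.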

Compound 3, half-maximal inhibitory concentration: > 50000 nM
Compound 3 gave a limit, no number (the forecaster's own chance of this, stated with the estimate: 40%); middle value at least 1.2-fold (0.09 log units) away from the limit.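

Among these compounds, this is the first step in the set between compounds that differ in one place: 2,5-dimethylphenyl in place of 2-bromophenyl on the aromatic nitrogen gives an at least 1.4-fold higher number from compound 2 to compound 3 (0.16 log units; that floor lies within the scatter). From the compounds shown here alone, the floor of that step does not show a real loss, yet the change brought no gain that this assay could detect, and the true size of the step remains unknown since compound 3 returned a limit and not a number. With this result, the only quantified point remains weak, and most of the set now rests at the top of the measurable range: the limit of > 50000 nM in this assay, at which 2 of the 3 values shown sit.

Going by these compounds, what remains open is whether any group on this nitrogen can bring a clearly stronger reading in this assay. A pyridine ring, or a phenyl ring carrying an amine or a carboxylic acid, would test this, as the two aryl groups compared here are both carbon-only rings without hydrogen-bond donors or acceptors.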